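Chloro for Fluoro on the Most Potent Member So Far

The source may hold more compounds than are shown below. What is called first, only, known or untested is meant among the compounds shown, and "the series" means these compounds.

Three measured compounds share one core. Compound 1 `COc1cccc(-c2noc(C3CC(=O)N(c4ccc(Cl)cc4)C3)n2)c1` carries a methoxyphenyl group and a chloro substituent, compound 2 `Cc1ccc(N2CC(c3nc(-c4cccc(F)c4)no3)CC2=O)cc1` a fluorophenyl group and a methyl substituent, and compound 3 `O=C1CC(c2nc(-c3cccc(F)c3)no2)CN1c1ccc(F)cc1` a fluorophenyl group and a fluoro substituent. In an in vitro functional assay on HEK293-A cells for positive allosteric modulation of metabotropic glutamate receptor 5 (Homo sapiens), read by FLIPR and calcium flux (on this read-out higher numbers stand for an effect only at larger amounts of compound and lower numbers for an effect already at smaller amounts), compound 1 gives 4800 nM, compound 2 gives 1200 nM, and compound 3 gives 88 nM. Compound 3 thus holds the lowest of the three numbers; the nearest of the others is separated from it by a 14-fold lower number from compound 2 to compound 3 (1.13 log units; beyond the scatter), and compound 1 lies further off still.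

Compound 4 `O=C1CC(c2nc(-c3cccc(F)c3)no2)CN1c1ccc(Cl)cc1` differs from compound 3 in one place: chloro in place of fluoro on an aromatic carbon. Among the compounds with values here, no measured pair swaps fluoro for chloro at that place. Within the data shown here, the only step at that place is the one from methyl to fluoro, large and beyond the scatter, which shows that this assay responds strongly to what sits there. Compound 1 also carries chloro there, but with a different aryl group, so its number cannot be read as a clean comparison. A moderate rise in the number is expected for compound 4, a 2.8-fold higher number from compound 3 to compound 4 (0.45 log units; beyond the scatter). Compound 4 is therefore estimated at 250 nM in this assay, within a range of 60 nM to 1000 nM.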

Compound 4, half-maximal effective concentration: 630 nM
Beside the measured number, compound 4's estimate is 2.5-fold (0.40 log units) below it; measured number inside the range.
By their numbers in this assay, from the lowest: compound 3; then compounds 4 and 2 (each within the scatter of the next); then compound 1.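

In this assay, within the data shown here, the direct swap of fluoro for chloro at this place gives a 7.2-fold higher number from compound 3 to compound 4 (0.85 log units; beyond the scatter) and so shows for the first time that 4-fluorophenyl and 4-chlorophenyl are not interchangeable here, while the comparison of chloro with methyl gives a 1.9-fold lower number from compound 2 to compound 4 (0.28 log units; within the scatter) and does not separate those two groups. Of the three groups seen at this place, then, only fluoro stands clear of the others, and the large methyl-to-fluoro step is not simply a matter of removing methyl in favour of any halogen. Among these compounds, compound 4 also gives the first clean reading at the other substituted aromatic carbon, where fluoro in place of methoxy gives a 7.6-fold lower number from compound 1 to compound 4 (0.88 log units; beyond the scatter) with chloro held constant, though no measured property offers an explanation for any of these steps.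

The compounds shown leave open how hydrogen, bromo or a nitrile at this place would compare with fluoro and chloro. They also leave open whether the methoxy-to-fluoro step would keep its size with 4-fluorophenyl in place of 4-chlorophenyl.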